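A few compounds are considered here, and "the series" means these few. Any claim that something is new, unique, unknown or untested is made for them only; others in the source may bear on it.

Of the compounds shown here, three have so far been measured in an assay on HL-60 cells for inhibition of cytochrome P450 26A1 (Homo sapiens), read by HPLC, using microsomes and NADPH, with a stated time of 30 min; a lower number here means a stronger inhibitor, a higher number a weaker inhibitor. Compound 1 `COC(=O)C(Cn1ccnc1)NC(=O)c1ccc(-c2ccccc2)cc1` gives 370 nM in this assay. Compound 2 `COC(=O)C(Cn1ccnc1)NC(=O)c1nc2ccccc2s1`, which carries a different aryl amide on the shared core, gives 410 nM in this assay. Compound 3 `CCOC(=O)C(Cn1ccnc1)NC(=O)c1nc2ccccc2s1` differs from compound 2 in one place, and compound 3 gives 740 nM in this assay. Within the data shown here, the single one-point step among the measured compounds is a 1.8-fold higher number from compound 2 to compound 3 (0.26 log units; within the scatter). On the numbers shown, compound 3 stands at the highest of the three values, yet its gaps to compound 2 and to compound 1 both fall within the scatter, so no order among the three can be claimed.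

Compound 4 `CC(C)OC(=O)C(Cn1ccnc1)NC(=O)c1nc2ccccc2s1` is the next member, not yet measured. It differs from compound 3 by methyl in place of hydrogen on a saturated chain carbon bound to an oxygen next to a carbonyl group and a saturated chain carbon. Among the measured compounds shown here, the only measured step that bears on this change is a 1.8-fold higher number from compound 2 to compound 3 (0.26 log units; within the scatter), a change at the same position that stayed within the scatter. The expected size of the step is therefore a 1.4-fold higher number from compound 3 to compound 4 (0.13 log units; within the scatter), a modest rise in the number at most, not clearly beyond the scatter. Compound 4 is accordingly expected to give about 1000 nM in this assay, with a range from 450 nM to 2300 nM.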

Compound 4, half-maximal inhibitory concentration: 630 nM
The estimate for compound 4 lay 1.6-fold (0.20 log units) above the measured number, within the range that was stated.
By their numbers in this assay, from the lowest: compounds 1, 2, 4 and 3 (each within the scatter of the next).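

In this assay the change from ethyl to isopropyl gives a 1.2-fold lower number from compound 3 to compound 4 (0.07 log units; within the scatter) and so does not repeat the sign of the earlier step, which was a 1.8-fold higher number from compound 2 to compound 3 (0.26 log units; within the scatter) at the same position; since both steps lie within the scatter, adding a methyl here shows no trend in either direction. The longer comparison, isopropyl in place of methyl on an oxygen next to a carbonyl group, gives a 1.5-fold higher number from compound 2 to compound 4 (0.19 log units; within the scatter) and also stays within the scatter, so this assay does not tell methyl, ethyl and isopropyl apart at this oxygen. Nothing at hand bears on why these numbers stay so close.

The compounds shown leave open whether the same holds for something larger on this oxygen, such as a longer chain or a benzyl group, or for a carboxylic acid or an amide in place of the isopropoxycarbonyl group. They also leave open whether ethyl and isopropyl would behave the same way alongside the aryl amide of compound 1, since all the changes at this position were read on the aryl amide of compound 2.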